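Trifluoromethyl to Nitro on the Pendant Phenyl Ring

This account rests on a few compounds, and the source may have more. Where it says the series, first, only, none or still open, it means among the compounds named here.

Compound 1, `COc1cc(-n2cnc3ccc(-c4ccc(C(C)=O)cc4)cc32)cc(OC)c1OC`: 1540 nM
Compound 2, `COc1cc(-n2cnc3ccc(-c4ccc(C(F)(F)F)cc4)cc32)cc(OC)c1OC`: 760 nM

Both compounds were measured in a functional assay on MCF7 cells (Homo sapiens) for antiproliferative activity, read by MTT assay, with a stated time of 72 h; on this read-out lower numbers stand for stronger inhibition and higher numbers for weaker inhibition. Compound 2 holds the lowest of the two numbers, reached by a 2.0-fold lower number from compound 1 to compound 2 (0.31 log units; beyond the scatter). The unmeasured compound 3 `COc1cc(-n2cnc3ccc(-c4cccc([N+](=O)[O-])c4)cc32)cc(OC)c1OC` differs from compound 2 by 3-nitrophenyl in place of 4-(trifluoromethyl)phenyl on an aromatic carbon. Within the data shown here, only one step is available, and it concerns trifluoromethyl in place of acetyl, not a nitro group, so it bears on this change only loosely; its modest size suggests that nothing beyond the scatter is expected here. Compound 3 is therefore estimated at 1000 nM, within 400 nM to 2500 nM, which means an expected 1.3-fold higher number from compound 2 to compound 3 (0.12 log units; within the scatter).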

Compound 3, half-maximal inhibitory concentration: 4560 nM
Compound 3: middle estimate off by 4.6-fold (0.66 log units), on the low side; the measured number lies above the stated range.
By their numbers in this assay, from the lowest: compound 2; then compound 1; then compound 3.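

In this assay, among these compounds, the only earlier step at this position lowered the number, whereas 3-nitrophenyl in place of 4-(trifluoromethyl)phenyl gives a 6.0-fold higher number from compound 2 to compound 3 (0.78 log units; beyond the scatter) and 3-nitrophenyl in place of 4-acetylphenyl gives a 3.0-fold higher number from compound 1 to compound 3 (0.47 log units; beyond the scatter). Both steps lie beyond the scatter, so compound 3 holds the highest number of the three. Nothing measured here accounts for this rise.

On these data alone, whether the rise follows the nitro group or its place on the ring stays open, since both differ at once from compound 1 and compound 2. As far as these compounds go, how an amine or a carboxylic acid would fare on this ring also remains open.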